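The compounds below may be only part of what the source reports. "The series", "measured", "known", "first", "only" and "open" are said of these compounds alone.

Measured so far in a functional assay on aorta (Rattus norvegicus) for inhibition; on this read-out lower numbers stand for an effect already at smaller amounts and higher numbers for an effect only at larger amounts of compound: compound 1 `CCCNC1=NS(=O)(=O)c2ccc(Cl)cc2N1` gives 73200 nM; compound 2 `CC(C)NC1=NS(=O)(=O)c2ccc(Cl)cc2N1` gives 53400 nM; compound 3 `CCCNC1=NS(=O)(=O)c2cc(Cl)ccc2N1` gives 55500 nM.

Compound 1 and compound 2 share a core and differ by isopropyl in place of propyl on an amine nitrogen; in this assay that change made a 1.4-fold lower number from compound 1 to compound 2 (0.14 log units; within the scatter). Compound 3 carries a different core; the difference between the two cores is not broken down here. Compound 3 lies within the scatter of both compound 2 and compound 1.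

Compound 4 `CC(C)NC1=NS(=O)(=O)c2cc(Cl)ccc2N1` is not yet measured. It differs from compound 3 by isopropyl in place of propyl on an amine nitrogen, the same change as between compound 1 and compound 2, at the same kind of place. Because the earlier step was a 1.4-fold lower number from compound 1 to compound 2 (0.14 log units; within the scatter), the step from compound 3 to compound 4 in this assay is expected to be a 1.2-fold lower number from compound 3 to compound 4 (0.09 log units; within the scatter). Compound 4 is estimated at 45000 nM, most likely between 20000 nM and 100000 nM.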

Compound 4, half-maximal effective concentration: 36300 nM
For compound 4 the middle estimate is 1.2-fold (0.09 log units) above the measured one; low and high end bracket the measured number.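

In this assay isopropyl in place of propyl on an amine nitrogen gave a 1.5-fold lower number from compound 3 to compound 4 (0.18 log units; within the scatter) on the core of compound 3, so the change shows no clear effect there by itself. Within the data shown here, what carries over is only that the step stays within the scatter on each core; this does not show that the change has an effect of its own, and it says nothing about cores beyond these two. Set side by side, the two steps do not differ: the same change on two cores in this assay, a 1.4-fold lower number (0.14 log units; within the scatter) from compound 1 to compound 2 and a 1.5-fold lower number (0.18 log units; within the scatter) from compound 3 to compound 4, 1.1-fold (0.05 log units) apart, within the scatter of two such steps

The compounds shown leave open how a longer chain such as butyl, or a ring such as cyclopropyl, would behave on that amine nitrogen. They also leave open whether a chain ending in an amine or a carboxylic acid would give a step beyond the scatter.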